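The source may hold more compounds than are shown below. What is called first, only, known or untested is meant among the compounds shown, and "the series" means these compounds.

Compound 3 `O=C(O)c1cc(-n2c(-c3ccc(Br)cc3)cc3c2CCCC3)ccc1O` gives 40% in a functional assay on the whole organism (strain Wistar) for inhibition, with Rattus norvegicus as the target, read by paw edema, with stated times of 30 min and 3 h, at a dose of 200 mg/kg by the oral route (on this read-out higher numbers stand for more inhibition at the one dose given (going by the name of the read-out) and lower numbers for less inhibition), the higher of the two plain numbers known there, while compound 2 `CC(=O)Nc1cc(-n2c(-c3ccccc3)cc3c2CCCC3)cc(C(=O)O)c1O` gives 0% in this assay. Compound 1 `O=C(O)c1cc(-n2c(-c3ccccc3)cc3c2CCCC3)ccc1O` gives >= 60% in this assay, and that value is a limit of the assay rather than a number (the limit of >= 60% in this assay, at which 1 of the 3 values shown sits). Compound 4 `O=C(O)c1cc(-n2c(-c3ccc([N+](=O)[O-])cc3)cc3c2CCCC3)ccc1O` is not yet measured; it differs from compound 3 by nitro in place of bromo on an aromatic carbon. Among the measured compounds shown here, two measured steps bear on this kind of change on the same aromatic ring: a number at least 20 percentage points lower from compound 1 to compound 3 (beyond the scatter) and a number at least 60 percentage points lower from compound 1 to compound 2 (beyond the scatter). Both lowered the inhibition from the parent without a substituent, but neither exchanges one substituent for another at that place, so a step of no more than modest size is expected from compound 3 to compound 4, a number 5 percentage points lower from compound 3 to compound 4 (within the scatter). Compound 4 is therefore estimated at 35% in this assay, within 15% to 55%.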

Compound 4, a percentage reported as inhibition, in the whole organism at one dose (the size of the read-out at that dose, not a potency): 30%
For compound 4 the middle estimate is 5 percentage points above the measured one; the measured number falls inside the stated range.
By their numbers in this assay, from the lowest: compound 2; then compounds 4 and 3 (each within the scatter of the next). At a limit, above all of these: compound 1.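

In this assay, exchanging bromo for nitro, para to a large group, gives a number 10 percentage points lower from compound 3 to compound 4 (within the scatter), so the data do not tell these two groups apart at this place. Nitro in place of hydrogen there gives a number at least 30 percentage points lower from compound 1 to compound 4 (beyond the scatter), so a second group on this ring stands clear of the unsubstituted compound. Compound 1 stands at a limit of the assay, not at a number: the limit of >= 60% in this assay, at which 1 of the 4 values shown sits.

The compounds shown leave open whether an amine or a methoxy group at this place would fall with bromo and nitro. They also leave open whether any group there keeps inhibition near that of compound 1.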